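The source may report more compounds than this note shows. Statements on the series, on what has been measured and on what is new or still open speak of the compounds shown alone.

In an ADME assay on cells (Hepatocyte, Mus musculus) for cytotoxicity, read by MTT assay, with a stated time of 24 h (on this read-out lower numbers stand for higher toxicity in this test and higher numbers for lower toxicity in this test), compound 1 `Cc1ccc(-c2nn(-c3ccccc3)cc2-c2nc3ccccc3n2S(=O)(=O)c2cc(C)ccc2C)cc1` gives 231000 nM and compound 2 `Cc1ccc(-c2nn(-c3ccccc3)cc2-c2nc3ccccc3n2S(=O)(=O)c2ccc(F)cc2)cc1` gives 167000 nM, so compound 2 stands within the usual scatter of compound 1. Compound 3 `O=S(=O)(c1ccc(F)cc1)n1c(-c2cn(-c3ccccc3)nc2-c2ccc(F)cc2)nc2ccccc21` differs from compound 2 by one change, (fluoro in place of methyl on an aromatic carbon), fluoro in place of methyl on an aromatic carbon. Among the measured compounds shown here, the only measured step, a 1.4-fold lower number from compound 1 to compound 2 (0.14 log units; within the scatter), concerns a different place, the group on the sulfonyl sulfur, so it offers only indirect guidance. With nothing measured at the new site, no shift beyond the scatter is expected. The expected change is a 1.0-fold higher number from compound 2 to compound 3 (0.01 log units; within the scatter). For compound 3 the estimated value is 170000 nM, with an expected range from 80000 nM to 350000 nM.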

Compound 3, half-maximal cytotoxic concentration: 174000 nM
Beside the measured number, compound 3's estimate is 1.0-fold (0.01 log units) below it; low and high end bracket the measured number.
By their numbers in this assay, from the lowest: compounds 2, 3 and 1 (each within the scatter of the next).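

Fluoro and methyl were compared directly at this position for the first time: going from 4-methylphenyl to 4-fluorophenyl gives a 1.0-fold higher number from compound 2 to compound 3 (0.02 log units; within the scatter) in this assay. This single swap on an aromatic carbon therefore cannot be told apart from repeat-to-repeat variation in this test. No measurement at hand offers a reason for this result. From the compounds shown here alone, whether an amine or a carboxylic acid at the same place would shift the number beyond the scatter remains open. So does whether the same swap would behave alike with 2,5-dimethylphenyl on the sulfonyl sulfur.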